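Swapping the Thioether Heteroaryl Group on a Cytotoxicity Scaffold

The source may hold more compounds than are shown below. What is called first, only, known or untested is meant among the compounds shown, and "the series" means these compounds.

Compound 1, `Cc1ccc2oc(SCC(=O)Nc3ccc(-c4nc(-c5ccccc5)c(-c5ccccc5)n4C)cc3)nc2c1`, gives 24.6% in a functional assay on MCF7 cells (Homo sapiens) for cytotoxicity, read by MTT assay, with a stated time of 24 h, tested at 6.4 ug/mL; on this read-out lower numbers stand for a weaker effect and higher numbers for a stronger effect at the one concentration tested.
Compound 2, `Cn1c(-c2ccc(NC(=O)CSc3nc4ccccc4s3)cc2)nc(-c2ccccc2)c1-c1ccccc1`, gives 27%.
Compound 3, `Cc1nnc(SCC(=O)Nc2ccc(-c3nc(-c4ccccc4)c(-c4ccccc4)n3C)cc2)s1`, gives 67.8%.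

Compound 1 stands lowest of the three: compound 2 sits a number 2.4 percentage points higher from compound 1 to compound 2 (within the scatter), while compound 3 lies a number 43.2 percentage points higher from compound 1 to compound 3 (beyond the scatter). Compound 4, `Cn1c(-c2ccc(NC(=O)CSC3=NCCS3)cc2)nc(-c2ccccc2)c1-c1ccccc1`, arises from compound 1 by this change: a group of 5 heavy atoms (3 carbon, 1 nitrogen, 1 sulfur; one five-membered non-aromatic ring with 2 hetero atoms) in place of a group of 10 heavy atoms (8 carbon, 1 nitrogen, 1 oxygen; one five-membered aromatic ring with 2 hetero atoms, one six-membered aromatic ring of carbon only), on a sulfur. The step of a number 2.4 percentage points higher from compound 1 to compound 2 (within the scatter) shows that trading one two-ring group for another moved nothing beyond the scatter, whereas a number 43.2 percentage points higher from compound 1 to compound 3 (beyond the scatter) shows a large gain when a single small ring replaced the two-ring group. Within the data shown here, compound 4 likewise carries a single small ring, so a clear rise is expected, although its ring is non-aromatic and no measured step covers that point. The expected step is a number 25.4 percentage points higher from compound 1 to compound 4 (beyond the scatter). Compound 4 is therefore estimated at 50%, with a range from 25% to 75%.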

Compound 4, a percentage reported as activity, at one concentration (the size of the read-out at that concentration, not a potency): 18.6%
Compound 4: the middle estimate sits 31.4 percentage points above what was measured; measured number outside the range, below it.
By their numbers in this assay, from the lowest: compounds 4, 1 and 2 (each within the scatter of the next); then compound 3.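

On this sulfur, a single small ring does not by itself give a high number in this assay, as the change to the non-aromatic ring shows: a number 49.2 percentage points lower from compound 3 to compound 4 (beyond the scatter). That ring stands level with both two-ring groups, with a number 6 percentage points lower from compound 1 to compound 4 (within the scatter) and a number 8.4 percentage points lower from compound 2 to compound 4 (within the scatter). No measurement here explains why the 5-methyl-1,3,4-thiadiazol-2-yl group of compound 3 stands apart.

From the compounds shown here alone, compound 3 and compound 4 differ in ring aromaticity, ring atoms and the methyl group together, so the change that matters remains open. A 1,3,4-oxadiazol-2-yl ring or the thiadiazole without its methyl would help separate these.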